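Series notes: purine-type core, substituent on the chain carbon

The source may report more compounds than this note shows. Statements on the series, on what has been measured and on what is new or still open speak of the compounds shown alone.

Of the compounds shown here, two have numbers so far. Compound 1 `COc1ccc(Cn2c(=O)n(C3OC(CO)[C@@H](O)[C@H]3O)c3nc(N)nc(O)c32)cc1` stands lowest of the two in a functional assay on the whole organism with Mus musculus as the target (a lower number here means a smaller maximal response, a higher number a larger maximal response), where compound 1 gives 14%. Compound 2 `C=CCn1c(=O)n(C2C=CC(CO)O2)c2nc(N)nc(O)c21` gives in this assay 84%, a higher number than that of compound 1 and beyond the scatter; compound 2 differs from compound 1 in more than one place, so no single step is listed between them.

Compound 3 `Nc1nc(O)c2c(n1)n(C1OC(CO)[C@@H](O)[C@H]1O)c(=O)n2CCN1CCCCC1` is not yet measured in this assay. Compared with compound 1 it carries (piperidin-1-yl)methyl in place of 4-methoxyphenyl on a saturated chain carbon bound to an aromatic nitrogen. For the measured compounds named here, no measured pair shows this change alone, so its size can only be guessed. Without a directly comparable step, a moderate increase from compound 1 is expected, a number 21 percentage points higher from compound 1 to compound 3 (beyond the scatter), with wide uncertainty in both directions. Compound 3 is estimated at 35% in this assay, with a range from 10% to 70%.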

Compound 3, largest response reached (reported as maximal response), in percent of the reference or control that the assay uses: 0%
The estimate for compound 3 lay 35 percentage points above the measured number, and the stated range ends above it.
By their numbers in this assay, from the lowest: compound 3; then compound 1; then compound 2.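

At the saturated chain carbon bound to an aromatic nitrogen, exchanging 4-methoxyphenyl for (piperidin-1-yl)methyl gives, in this assay, a number 14 percentage points lower from compound 1 to compound 3 (beyond the scatter). For the compounds shown here, this is the first single-place reading, and it shows that the response at this position depends on the group carried there and that a six-membered aromatic ring of carbon only is not required for a low number, since compound 3 gives 0% with a six-membered non-aromatic ring in its place. No measurement at hand accounts for the step.

The step changes the ring and brings in a ring nitrogen at once, so the contribution of each remains unresolved. A 2-cyclohexylethyl or 2-(morpholin-4-yl)ethyl group at this place would help separate them, and a longer chain would test the role of the linker.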